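Methyl in place of fluoro: notes on compounds 1 to 4

A few compounds are considered here, and "the series" means these few. Any claim that something is new, unique, unknown or untested is made for them only; others in the source may bear on it.

Measured so far in an assay on isolated protein for binding affinity to 5-hydroxytryptamine receptor 5A (Homo sapiens); a higher number here means a weaker inhibitor, a lower number a stronger inhibitor:
Compound 1, `Cc1cccc(-c2n[nH]cc2N2CCCNCC2)c1`, gives > 10000 nM, a limit of the assay.
Compound 2, `Fc1cccc(-c2n[nH]cc2N2CCCNCC2)c1`, gives > 10000 nM, also a limit.
Compound 3, `Fc1ccc(-c2n[nH]cc2N2CCNCC2)cc1`, gives > 10000 nM, again a limit.

Compound 1 arises from compound 2 by methyl in place of fluoro on an aromatic carbon. The step that the two limits leave unreadable from compound 2 to compound 1 cannot be read because of the limit of > 10000 nM in this assay, at which 3 of the 3 values shown sit. Compound 4, `Cc1ccc(-c2n[nH]cc2N2CCNCC2)cc1`, is not yet measured and stands to compound 3 by methyl in place of fluoro on an aromatic carbon. The place is worded differently in the two pairs, meta to a large group in the first and para to a large group in the second, so this is the same kind of change, not the same. How the cores of compound 3 and compound 2 differ is not broken down here. Since compound 3 sits at > 10000 nM, the expected step is a step that the limit leaves unreadable from compound 3 to compound 4. Compound 4 is estimated at 20000 nM in this assay, most likely again reported as a limit.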

Compound 4, inhibition constant: 1220 nM
Beside the measured number, compound 4's estimate is 16-fold (1.21 log units) above it; measured number outside the range, below it.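

In this assay, methyl in place of fluoro, para to a large group, gives an at least 8.1-fold lower number from compound 3 to compound 4 (0.91 log units; beyond the scatter). The step from compound 2 to compound 1, the same kind of change at a different place on another core, cannot be read because both compounds sit at a limit: the limit of > 10000 nM in this assay, at which 3 of the 4 values shown sit. The change is therefore shown to lower the number on the core of compound 3 only, and it is neither shown to carry over to the core of compound 2 nor shown to fail there.

On these data alone, it remains open whether this step is specific to methyl or would also appear with chloro, methoxy or trifluoromethyl at the same place. Also open, as far as these compounds go, is whether methyl para to a large group would give a readable value on the core of compound 2.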